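Trimming a Chain Branch in a Bombesin Receptor Agonist Series

The source may report more compounds than this note shows. Statements on the series, on what has been measured and on what is new or still open speak of the compounds shown alone.

Of the compounds shown here, two from this series have been measured so far. Compound 1 `O=C(O)c1ccccc1-c1ccc(CCc2ncc(CC3CCOCC3)[nH]2)cc1` and compound 2 `CCCCc1cnc(C(CC)Cc2ccc(-c3ccccc3C(=O)O)cc2)[nH]1` were both tested in an in vitro functional assay on cells for agonist activity at Bombesin receptor subtype-3 (Homo sapiens), read by luminescence and calcium flux; a lower number here means that less compound is needed, a higher number that more compound is needed for the effect. In this assay compound 1 gives 338 nM. In this assay compound 2 gives 2720 nM, the higher of the two numbers, and the gap to compound 1 lies beyond the usual scatter of the measurement, so compound 2 needs more material for the same effect. The two compounds differ in several places at once, so no single change can be credited with this gap.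

Compound 3 `CCCCc1cnc(C(C)Cc2ccc(-c3ccccc3C(=O)O)cc2)[nH]1` differs from compound 2 in one place only: hydrogen in place of methyl on a saturated chain carbon, two bonds along the chain from an aromatic carbon. Going by the values given here, no measured pair so far isolates this change, so there is no direct precedent for it. Such a small trimming of a side branch usually shifts the read-out little, and the step from compound 2 to compound 3 is expected to be a 1.4-fold lower number from compound 2 to compound 3 (0.13 log units; within the scatter), within the scatter, with no clear direction. Compound 3 is therefore expected to give about 2000 nM, with a plausible range from 700 nM to 6000 nM.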

Compound 3, half-maximal effective concentration: 2760 nM
The estimate for compound 3 lay 1.4-fold (0.14 log units) below the measured number; low and high end bracket the measured number.
By their numbers in this assay, from the lowest: compound 1; then compounds 2 and 3 (each within the scatter of the next).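

Cutting the branch on this saturated chain carbon, two bonds along the chain from an aromatic carbon, from ethyl to methyl gives a 1.0-fold higher number from compound 2 to compound 3 (0.01 log units; within the scatter) in this assay. Going by these compounds alone, this is the first pair to isolate a single change, and it shows that compound 2 and compound 3 cannot be told apart in this read-out, so this one-carbon trim on its own does not account for any measurable difference at this place. No independent measurement bears on this result, so the data offer no explanation for the flat step.

Going by these compounds, the pair covers only the ethyl and methyl branches, so it remains open whether the read-out would also hold with a longer chain such as propyl, or with a hydroxyl group or a cyclopropyl ring on the same carbon. On these data alone, it also remains open whether the branch can go altogether, leaving only hydrogen on that carbon, since a flat step between two small alkyl groups says little about the loss of the whole branch.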